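Swapping the amide head for a pyridyl ester

The compounds below may be only part of what the source reports. "The series", "measured", "known", "first", "only" and "open" are said of these compounds alone.

For the measured compounds named here, compound 3 `CNC(=O)c1cnc(C(=O)CCc2ccc(COc3ccccc3)cc2)o1` sits in the middle of the three numbers known so far: in an assay for inhibition of Fatty-acid amide hydrolase 1 (Rattus norvegicus) (a lower number here means a stronger inhibitor, a higher number a weaker inhibitor), compound 3 gives 3.6 nM. Compound 1 `COC(=O)c1ccc(-c2cnc(C(=O)CCc3ccc(-c4ccccc4)cc3)o2)nc1` gives 2.2 nM in this assay, and compound 2 `CN(C)C(=O)c1cnc(C(=O)CCc2ccc(COc3ccccc3)cc2)o1` gives 6.7 nM; both of these lie within the scatter of compound 3, so no order among the three can be read from them. Going by the values given here, the only measured step, a 1.9-fold lower number from compound 2 to compound 3 (0.27 log units; within the scatter), concerns the amide nitrogen and is itself within the scatter. Compound 4 `COC(=O)c1ccc(-c2cnc(C(=O)CCc3ccc(COc4ccccc4)cc3)o2)nc1` differs from compound 3 in one place: 5-(methoxycarbonyl)pyridin-2-yl in place of methylcarbamoyl on an aromatic carbon. Among the compounds with values here, no measured step touches this change directly; compound 1 carries the same 5-(methoxycarbonyl)pyridin-2-yl group on a different tail and shows a number close to that of compound 3, but no step between those two compounds is available. On that footing the expected outcome is a step of a 1.4-fold lower number from compound 3 to compound 4 (0.16 log units; within the scatter), not beyond the scatter. Compound 4 is therefore estimated at 2.5 nM in this assay, with a range of 0.8 nM to 8 nM.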

Compound 4, inhibition constant: 3.5 nM
Beside the measured number, compound 4's estimate is 1.4-fold (0.15 log units) below it, and the stated range covers the measured number.
By their numbers in this assay, from the lowest: compounds 1, 4, 3 and 2 (each within the scatter of the next, the first and the last beyond it).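

In this assay, 5-(methoxycarbonyl)pyridin-2-yl in place of methylcarbamoyl gives a 1.0-fold lower number from compound 3 to compound 4 (0.01 log units; within the scatter) at this aromatic carbon next to the ring oxygen, so the number does not separate the two groups, although the entering group carries a six-membered aromatic ring and no hydrogen-bond donor. The same group in place of dimethylcarbamoyl gives a 1.9-fold lower number from compound 2 to compound 4 (0.28 log units; within the scatter) and, with this group held constant, phenoxymethyl in place of phenyl gives a 1.6-fold higher number from compound 1 to compound 4 (0.20 log units; within the scatter) on the other side of the molecule, so none of these single changes separates the compounds. No measurement is available that would explain these results.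

The compounds shown leave open what a carboxylic acid in place of the methyl ester on the pyridin-2-yl group would give. They also leave open what a simple phenyl group at this position would give.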